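Ester and side-chain variation in an alkynyl enol ether series

The source may report more compounds than this note shows. Statements on the series, on what has been measured and on what is new or still open speak of the compounds shown alone.

Compound 1 `CCOC(=O)C#CC(O/C=C/C(=O)OCC)C(C)C`, compound 2 `CCCC(C#CC(=O)OC)O/C=C/C(=O)OC` and compound 3 `COC(=O)C#CC(CC(C)C)O/C=C/C(=O)OC` are measured; compound 4 `CCOC(=O)C#CC(O/C=C/C(=O)OC)C(C)C` is not yet measured. In a functional assay on HBL-100 cells (Homo sapiens) for antiproliferative activity, read by sulforhodamine B assay, with a stated time of 48 h (on this read-out lower numbers stand for stronger inhibition of growth and higher numbers for weaker inhibition of growth), compound 1 gives 3000 nM, compound 2 gives 270 nM and compound 3 gives 330 nM. Compound 1 stands highest of the three, with compound 3 nearest and compound 2 furthest, both beyond the scatter. The difference between the cores of compound 1 and compound 3 is not broken down here. Between compound 3 and compound 2 the change is hydrogen in place of methyl on a saturated chain carbon bound to two saturated chain carbons, and it gave a 1.2-fold lower number from compound 3 to compound 2 (0.09 log units; within the scatter). Compound 4 arises from compound 1 by hydrogen in place of methyl on a saturated chain carbon bound to an oxygen next to a carbonyl group. This is the same kind of change, but the place differs: in the first case the saturated chain carbon is bound to two saturated chain carbons, in the second to an oxygen next to a carbonyl group. Compound 2 with 270 nM and compound 3 with 330 nM carry methoxycarbonyl groups, whereas compound 1 with ethoxycarbonyl groups gives 3000 nM, and on this the expectation rests. For compound 4 the expected step is a 2.0-fold lower number from compound 1 to compound 4 (0.30 log units; within the scatter). The estimate for compound 4 in this assay is 1500 nM, expected between 500 nM and 5000 nM.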

Compound 4, concentration for 50% growth inhibition: 880 nM
Estimate against measurement, compound 4: 1.7-fold (0.23 log units) above, and the stated range covers the measured number.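

In this assay, hydrogen in place of methyl on a saturated chain carbon bound to an oxygen next to a carbonyl group gives a 3.4-fold lower number from compound 1 to compound 4 (0.53 log units; beyond the scatter), so ethoxycarbonyl to methoxycarbonyl at this place counts for something on the core of compound 1. The same kind of change does not carry over at one size from one core to the other: the same change on two cores in this assay, a 1.2-fold lower number (0.09 log units; within the scatter) from compound 3 to compound 2 and a 3.4-fold lower number (0.53 log units; beyond the scatter) from compound 1 to compound 4, 2.8-fold (0.45 log units) apart, beyond the scatter of two such steps. The two steps also differ in place, so this comparison does not separate the core from the place, and one step on each core gives no rule for a further core in the series.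

From the compounds shown here alone, compound 4 still carries a second ethoxycarbonyl group, and what hydrogen in place of methyl would do there on this core remains open. Also open, going by these compounds, is how a carboxylic acid or a longer chain, such as propoxycarbonyl, would read in place of either ester group.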